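Halogen swap at the aryl carbon: bromo, iodo, chloro

This account rests on a few compounds, and the source may have more. Where it says the series, first, only, none or still open, it means among the compounds named here.

Working notes on the series. All three measured compounds share one core and are compared in an ADME assay on MT4 cells (Homo sapiens) for cytotoxicity, read by MTT assay, with a stated time of 96 h; a lower number here means that less compound is tolerated, a higher number that more compound is tolerated. Compound 1 `S=C(Nc1ccc(Br)cc1)Nc1nc[nH]n1` reaches only the limit of > 100000 nM in this assay, which is a limit and not a number. Compound 2 `S=C(Nc1ccc(I)cc1)Nc1nc[nH]n1` gives 46000 nM in this assay, and compound 3 `S=C(Nc1cccc(Br)c1)Nc1nc[nH]n1` gives 50000 nM. Compound 2 and compound 3 sit within the scatter of each other, so no order between them is claimed; the third value shown is the limit for compound 1. Among the compounds with values here, the single step measured in one place is an at least 2.1-fold lower number from compound 1 to compound 2 (0.33 log units; beyond the scatter); its size is bounded by the limit of > 100000 nM in this assay, at which 1 of the 3 values shown sits.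

Compound 4 `S=C(Nc1ccc(Cl)cc1)Nc1nc[nH]n1` differs from compound 2 by chloro in place of iodo on an aromatic carbon. Within the data shown here, the only step that bears on this change runs in the opposite direction, from bromo to iodo, and lowered the number in this assay by at least a modest amount. Going from iodo to chloro is expected to reverse that, giving a modestly higher number for compound 4, with a fair chance that only the limit is reported. Compound 4 is therefore estimated at 90000 nM in this assay, within 40000 nM to 200000 nM. The expected step is a 2.0-fold higher number from compound 2 to compound 4 (0.29 log units; within the scatter).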

Compound 4, half-maximal cytotoxic concentration: 47000 nM
For compound 4 the middle estimate is 1.9-fold (0.28 log units) above the measured one; the range from low to high includes it.
By their numbers in this assay, from the lowest: compounds 2, 4 and 3 (each within the scatter of the next). At a limit, above all of these: compound 1.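

In this assay, replacing iodo with chloro on an aromatic carbon para to a group of 9 heavy atoms gives a 1.0-fold higher number from compound 2 to compound 4 (0.01 log units; within the scatter) and so does not undo the drop first seen on leaving bromo. Chloro in place of bromo at this same place gives an at least 2.1-fold lower number from compound 1 to compound 4 (0.32 log units; beyond the scatter) and so, among these three halogens, the numbers do not run in the order chloro, bromo, iodo: bromo stands apart, while chloro and iodo lie within the scatter of each other. The step away from bromo has no fixed size, since compound 1 gives only a limit and not a number: the limit of > 100000 nM in this assay, at which 1 of the 4 values shown sits.

Going by these compounds, how far compound 1 really lies from the other two halogen compounds therefore stays open, and so does whether its separate standing would hold once a number replaces the limit. The compounds shown also give no reading at this place for a fluoro, a methoxy, an amine or a carboxylic acid, so it remains open whether the flat reading for chloro and iodo extends beyond these halogens.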